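This account rests on a few compounds, and the source may have more. Where it says the series, first, only, none or still open, it means among the compounds named here.

Of the compounds shown here, three that share one core have been measured in a physicochemical assay for acid dissociation. Compound 1 `COc1cccc(CNCCCNc2ccnc3cc(CCC(C)C)ccc23)c1O` gives 9.47, and compound 2 `COc1cccc(CNCCCNc2ccnc3cc(-c4ccccc4)ccc23)c1O` gives 9.47. Compound 3 `COc1cccc(CNCCCNc2ccnc3cc(Oc4ccc(C(C)(C)C)cc4)ccc23)c1O` gives 9.28, the lowest of the three numbers, though its gaps to compound 1 and to compound 2 both fall within the scatter. The steps among these compounds are no change at the digits printed from compound 1 to compound 2 (within the scatter), a number 0.19 log units lower from compound 1 to compound 3 (within the scatter) and a number 0.19 log units lower from compound 2 to compound 3 (within the scatter); none of the three exchanges at this aromatic carbon moved the proton dissociation beyond the scatter. Compound 4 `COc1cccc(CNCCCNc2ccnc3cc(-c4ccc(C(F)(F)F)cc4)ccc23)c1O` differs from compound 3 by 4-(trifluoromethyl)phenyl in place of 4-(tert-butyl)phenoxy on an aromatic carbon. Among the measured compounds shown here, the change sits at the same aromatic carbon as the three measured exchanges, and the step from compound 2 to compound 3, in which a phenyl was replaced by a 4-(tert-butyl)phenoxy, is the closest precedent. Since every measured step at this place stayed within the scatter, compound 4 is expected to show no step beyond the scatter in this assay, and the estimate means a step of a number 0.10 log units higher from compound 3 to compound 4 (within the scatter). Compound 4 is therefore estimated at 9.38, with a range from 9.1 to 9.65.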

Compound 4, acid dissociation constant: 9.47
Beside the measured number, compound 4's estimate is 0.09 log units below it; the range from low to high includes it.
By their numbers in this assay, from the lowest: compounds 3, 1, 2 and 4 (each within the scatter of the next).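

In this assay, among the compounds shown here, trifluoromethyl in place of hydrogen on the phenyl group gives no change at the digits printed from compound 2 to compound 4 (within the scatter) and so adds a test the earlier compounds did not offer, a substitution on the entering ring itself rather than an exchange of the whole group. The exchanges of whole groups at this aromatic carbon give a number 0.19 log units higher from compound 3 to compound 4 (within the scatter) for 4-(trifluoromethyl)phenyl in place of 4-(tert-butyl)phenoxy and no change at the digits printed from compound 1 to compound 4 (within the scatter) for 4-(trifluoromethyl)phenyl in place of isopentyl, so all four groups shown here sit within the scatter of one another. No measurement at hand speaks to what lies behind these readings.

The compounds shown leave open whether a primary amine or a carboxylic acid at this aromatic carbon would also stay within the scatter in this assay as the four groups do. They also leave open how a longer chain between the two nitrogens of the shared core would read there.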